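Dithioester series: aryl for alkyl on the thioester sulfur

The compounds below may be only part of what the source reports. "The series", "measured", "known", "first", "only" and "open" are said of these compounds alone.

compound 1 `CC1(C)CC(=O)C(C(=S)SCc2ccccc2)=C(Nc2ccc(Cl)cc2Cl)C1`: > 100 ug/mL
compound 2 `CCCCCCCCCCCSC(=S)C1=C(Nc2ccc(Br)cc2)CC(C)(C)CC1=O`: > 100 ug/mL

In a functional assay on cells (blood, Homo sapiens) for inhibition, read by chemiluminescence, with a stated time of 30 min (on this read-out lower numbers stand for stronger inhibition and higher numbers for weaker inhibition), compound 1 gives > 100 ug/mL, which is a limit of the assay and not a number. In this assay compound 2 gives > 100 ug/mL, again only a limit. Within the data shown here, compound 2 therefore stands at the limit of > 100 ug/mL in this assay, at which 2 of the 2 values shown sit, and no measured step between compounds exists in this set. Compound 3 `CC1(C)CC(=O)C(C(=S)SCc2ccccc2)=C(Nc2ccc(Br)cc2)C1` carries phenyl in place of decyl on a saturated chain carbon bound to a sulfur. A step from compound 2 to compound 3 of a number no higher from compound 2 to compound 3 (the limit leaves the size open) is expected, that is none beyond the scatter. Compound 3 is estimated at 100 ug/mL, with a range from 30 ug/mL to 300 ug/mL.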

Compound 3, half-maximal inhibitory concentration: > 100 ug/mL
Compound 3 was reported as a limit; the forecaster's own chance of this, stated with the estimate: 75%; the middle value sits exactly at the limit.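

No step can be read between compound 1, compound 2 and compound 3 in this assay because all three sit at a limit: the limit of > 100 ug/mL in this assay, at which 3 of the 3 values shown sit. The compounds shown leave open whether any member of this dithioester series gives a readable value in this assay and, if so, how the groups on sulfur and nitrogen affect it.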